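The source may report more compounds than this note shows. Statements on the series, on what has been measured and on what is new or still open speak of the compounds shown alone.

Compound 1 `CCn1c(C(=O)NCCN)ccc1C(CC)(CC)c1ccc(OCC(=O)C(C)(C)C)c(C)c1` gives 120 nM in an assay on HL-60 cells for agonist activity at vitamin D3 receptor (Homo sapiens), read by microscopy, with a stated time of 96 h; a higher number here means that more compound is needed for the effect, a lower number that less compound is needed.
Compound 2 `C#CCCOC(=O)c1ccc(C(CC)(CC)c2ccc(OCC(=O)C(C)(C)C)c(C)c2)n1CC` gives 28800 nM in this assay.
Compound 3 `CCOC(=O)CN(C)C(=O)c1ccc(C(CC)(CC)c2ccc(OCC(O)C(C)(C)C)c(C)c2)n1CC` gives 210 nM in this assay.

Among these three numbers compound 3 stands second highest. Its nearest neighbour is compound 1, and the gap between the two lies within the scatter, so no order between them can be read. Going by the values given here, compound 2 lies far above both: the only measured step, a 240-fold higher number from compound 1 to compound 2 (2.38 log units; beyond the scatter), comes from a change on a carbonyl carbon, where (but-3-yn-1-yl)oxy replaces (2-aminoethyl)amino.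

Among the compounds with values here, compound 4 `C=CCN(C)C(=O)c1ccc(C(CC)(CC)c2ccc(OCC(O)C(C)(C)C)c(C)c2)n1CC` differs from compound 3 at another place. vinyl in place of ethoxycarbonyl on a saturated chain carbon bound to an amide-type nitrogen The one measured step concerns a different site, so nothing measured here bears directly on this change, and no clear direction can be drawn from it. The step expected in this assay is therefore a small one, a 1.2-fold higher number from compound 3 to compound 4 (0.08 log units; within the scatter). Compound 4 is expected to give about 250 nM, with a range from 80 nM to 800 nM.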

Compound 4, half-maximal effective concentration: 3950 nM
Estimate against measurement, compound 4: 16-fold (1.20 log units) below; measured number outside the range, above it.
By their numbers in this assay, from the lowest: compounds 1 and 3 (each within the scatter of the next); then compound 4; then compound 2.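

The earlier compounds shown here showed a large step only on a carbonyl carbon, and this result shows that a saturated chain carbon bound to an amide-type nitrogen also matters in this assay: vinyl in place of ethoxycarbonyl gives a 19-fold higher number from compound 3 to compound 4 (1.27 log units; beyond the scatter). The swap replaces a group of 5 heavy atoms and 2 hydrogen-bond acceptors with one of 2 heavy atoms and no hydrogen-bond acceptors, so size and acceptor count change together and this single step cannot separate them. Nothing available here explains the rise in the number.

On these data alone, what this place accepts beyond these two groups remains open. A carboxylic acid, an amine or a longer carbon chain in place of ethoxycarbonyl would show whether the oxygen atoms or the length of the group go with the lower number.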